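The source may report more compounds than this note shows. Statements on the series, on what has been measured and on what is new or still open speak of the compounds shown alone.

Measured compounds:
Compound 1 `Cn1c(=O)c(=O)n(C2CCCC2)c2nc(N/N=C/c3ccc(S(C)(=O)=O)cc3)ncc21` — in a functional assay on PC-3 cells (Homo sapiens) for antiproliferative activity, read by MTT assay (on this read-out lower numbers stand for stronger inhibition and higher numbers for weaker inhibition), compound 1 gives 26600 nM.
Compound 2 `Cn1c(=O)c(=O)n(C2CCCC2)c2nc(N/N=C/c3cccs3)ncc21` — in this assay compound 2 gives 75600 nM.

Compound 2 holds the highest of the two numbers seen so far in this assay; its nearest neighbour is compound 1, and the change between them amounts to a 2.8-fold higher number from compound 1 to compound 2 (0.45 log units; beyond the scatter). The next compound, compound 3 `Cc1cc(C)c(/C=N/Nc2ncc3c(n2)n(C2CCCC2)c(=O)c(=O)n3C)c(C)c1`, arises from compound 2 through (2,4,6-trimethylphenyl in place of thiophen-2-yl on a carbon with a double bond to nitrogen).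

Within the data shown here, no measured step covers this particular exchange. Among the measured compounds shown here, the single step available, a 2.8-fold higher number from compound 1 to compound 2 (0.45 log units; beyond the scatter), concerns the replacement of a different group by the thiophen-2-yl that now leaves, so it only shows that changing the group on the carbon with a double bond to nitrogen moves the number by a modest amount. Without a closer precedent, compound 3 is expected to land near compound 2, with a wide band on either side, and the step from compound 2 is estimated as a 1.5-fold lower number from compound 2 to compound 3 (0.18 log units; within the scatter). Compound 3 is therefore estimated at 50000 nM in this assay, within a range from 15000 nM to 160000 nM.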

Compound 3, half-maximal inhibitory concentration: 13900 nM
Compound 3: middle estimate off by 3.6-fold (0.56 log units), on the high side, outside the stated range (below it).
By their numbers in this assay, from the lowest: compounds 3 and 1 (each within the scatter of the next); then compound 2.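

Across this assay, the step of a 5.4-fold lower number from compound 2 to compound 3 (0.74 log units; beyond the scatter) shows that the group on the carbon with a double bond to nitrogen can move the number by more than the earlier step alone had shown, and compound 2, with its thiophen-2-yl, is the weakest of the three compounds. The step of a 1.9-fold lower number from compound 1 to compound 3 (0.28 log units; within the scatter) does not separate the 2,4,6-trimethylphenyl of compound 3 from the 4-(methylsulfonyl)phenyl of compound 1, so two quite differently substituted phenyl groups give readings that cannot be told apart, while both stand clear of the thiophen-2-yl. No information is available on why the thiophen-2-yl stands apart from the two phenyl groups.

The compounds shown leave open how an unsubstituted phenyl would compare, and whether a single methyl group on the ring would give the same reading as the three methyl groups of compound 3. They also leave open what a phenyl carrying an amine or a carboxylic acid would give at this place, and whether a saturated ring such as cyclohexyl would be tolerated there.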